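Series notes: amino to bromo on the phenoxy ring

A few compounds are considered here, and "the series" means these few. Any claim that something is new, unique, unknown or untested is made for them only; others in the source may bear on it.

In a functional assay on A549 cells (Homo sapiens) for antiproliferative activity, read by MTT assay, with a stated time of 48 h (on this read-out higher numbers stand for weaker inhibition and lower numbers for stronger inhibition), compound 1 `O=c1cc(-n2cc(CNc3ccccc3)nn2)c2cc(Br)ccc2o1` gives 13200 nM, compound 2 `O=c1cc(-n2cc(COc3ccccc3Br)nn2)c2cc(Br)ccc2o1` gives 8430 nM and compound 3 `Nc1ccc(OCc2cn(-c3cc(=O)oc4ccc(Br)cc34)nn2)cc1` gives 11900 nM. Compound 3 holds the second highest of the three numbers; its nearest neighbour is compound 1 and its furthest is compound 2, and a 1.1-fold lower number from compound 1 to compound 3 (0.05 log units; within the scatter) as well as a 1.4-fold higher number from compound 2 to compound 3 (0.15 log units; within the scatter) stay within the scatter, as does a 1.6-fold lower number from compound 1 to compound 2 (0.19 log units; within the scatter). Compound 4 `O=c1cc(-n2cc(COc3ccc(Br)cc3)nn2)c2cc(Br)ccc2o1` arises from compound 3 by bromo in place of amino on an aromatic carbon. Among the compounds with values here, no measured step exchanges these two groups at the same place; the closest comparison, a 1.4-fold higher number from compound 2 to compound 3 (0.15 log units; within the scatter), trades an aryl bearing bromo for one bearing amino without leaving the scatter. The expected step is therefore a 1.3-fold lower number from compound 3 to compound 4 (0.10 log units; within the scatter), nothing beyond the scatter. The estimate for compound 4 is 9500 nM, with a range from 4500 nM to 20000 nM.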

Compound 4, half-maximal inhibitory concentration: 24500 nM
For compound 4 the middle estimate is 2.6-fold (0.41 log units) below the measured one, outside the stated range (above it).
By their numbers in this assay, from the lowest: compounds 2, 3, 1 and 4 (each within the scatter of the next, the first and the last beyond it).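

Unlike every step among compounds 1, 2 and 3, bromo in place of amino on this aromatic carbon leaves the scatter (a 2.1-fold higher number from compound 3 to compound 4 (0.31 log units; beyond the scatter)). The site of the bromo also counts, as 4-bromophenyl in place of 2-bromophenyl gives (a 2.9-fold higher number from compound 2 to compound 4 (0.46 log units; beyond the scatter)), whereas the change from anilino to 4-bromophenoxy stays within the scatter (a 1.9-fold higher number from compound 1 to compound 4 (0.27 log units; within the scatter)). Nothing at hand accounts for these steps.

On these data alone, whether a chloro or a methoxy on the same aromatic carbon would read like the amino of compound 3 or like the bromo of compound 4 remains open.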